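The source may report more compounds than this note shows. Statements on the series, on what has been measured and on what is new or still open speak of the compounds shown alone.

Compound 1 `O=C(NO)c1ccc(CN(Cc2ccccc2)S(=O)(=O)c2c(F)c(F)c(F)c(F)c2F)cc1`: in an assay on isolated protein for inhibition of protein deacetylase HDAC6 (Homo sapiens), read by mobility shift assay (on this read-out higher numbers stand for weaker inhibition and lower numbers for stronger inhibition), compound 1 gives 9 nM
Compound 2 `O=C(NO)c1ccc(CN(Cc2ccncc2)S(=O)(=O)c2c(F)c(F)c(F)c(F)c2F)cc1`: in this assay compound 2 gives 14 nM
Compound 3 `O=C(NO)c1ccc(CN(Cc2ccncc2)S(=O)(=O)c2cc(F)c(F)c(F)c2F)cc1`: in this assay compound 3 gives 11 nM

All three compounds share one core that carries the hydroxamic acid, and they differ only at the group on the sulfonamide nitrogen and in the count of fluoro atoms on the sulfonyl ring. Among the three numbers, compound 3 sits between the other two, and each of its neighbours lies within the scatter of it, so no order can be read from them.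

Compound 4 `O=C(NO)c1ccc(CN(Cc2ccccc2)S(=O)(=O)c2cc(F)c(F)c(F)c2F)cc1` has not yet been measured. It differs from compound 3 by phenyl in place of pyridin-4-yl on a saturated chain carbon bound to a sulfonamide nitrogen. The same swap, run the other way, was seen once already: a 1.6-fold higher number from compound 1 to compound 2 (0.19 log units; within the scatter). A second step, a 1.3-fold lower number from compound 2 to compound 3 (0.10 log units; within the scatter), concerns the fluoro count and does not bear on this change. Among the compounds with values here, because the only relevant step, a 1.6-fold higher number from compound 1 to compound 2 (0.19 log units; within the scatter), stayed within the scatter, the expected step is a 1.4-fold lower number from compound 3 to compound 4 (0.14 log units; within the scatter), a number that is at most slightly lower and not beyond the scatter. Compound 4 is therefore estimated at 8 nM, with a range from 4 nM to 16 nM.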

Compound 4, half-maximal inhibitory concentration: 5 nM
For compound 4 the middle estimate is 1.6-fold (0.20 log units) above the measured one, and the stated range covers the measured number.
By their numbers in this assay, from the lowest: compounds 4, 1, 3 and 2 (each within the scatter of the next, the first and the last beyond it).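

In this assay, phenyl in place of pyridin-4-yl on a saturated chain carbon bound to a sulfonamide nitrogen now gives a step beyond the scatter, a 2.2-fold lower number from compound 3 to compound 4 (0.34 log units; beyond the scatter), whereas its earlier reading stayed within it. The swap points the same way on both cores, with phenyl giving the lower number, and the two readings agree: the same change on two cores in this assay, a 1.6-fold higher number (0.19 log units; within the scatter) from compound 1 to compound 2 and a 2.2-fold higher number (0.34 log units; beyond the scatter) from compound 4 to compound 3, 1.4-fold (0.15 log units) apart, within the scatter of two such steps Hydrogen in place of fluoro on an aromatic carbon, now read with phenyl in place, gives a 1.8-fold lower number from compound 1 to compound 4 (0.26 log units; within the scatter), so this change stays within the scatter on both cores: the same change on two cores in this assay, a 1.3-fold lower number (0.10 log units; within the scatter) from compound 2 to compound 3 and a 1.8-fold lower number (0.26 log units; within the scatter) from compound 1 to compound 4, 1.4-fold (0.15 log units) apart, within the scatter of two such steps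

The compounds shown leave open how a cyclohexyl group or a longer chain such as phenylethyl would read at this place. They also leave open how a sulfonyl ring with no fluoro atoms would read.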